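The source may hold more compounds than are shown below. What is called first, only, known or untested is meant among the compounds shown, and "the series" means these compounds.

Measured so far:
- compound 1 `COc1ccc(-c2nc3cccc(-c4cc(OC)c(OC)c(OC)c4)c3o2)cc1OC`: 1300 nM
- compound 2 `COc1ccc(-c2nc3cccc(-c4cc(OC)c(OC)c(OC)c4)c3o2)cc1F`: 1700 nM

Both values come from a functional assay on U-251 cells (Homo sapiens) for antiproliferative activity, read by MTT assay, with a stated time of 48 h; on this read-out lower numbers stand for stronger inhibition and higher numbers for weaker inhibition. Compound 2 stands at 1700 nM, and compound 1 stands at 1300 nM. These two lie within the scatter of each other, so neither compound has a rank of its own.

The next compound is compound 3 `COc1cc(-c2cccc3nc(-c4ccc(F)cc4)oc23)cc(OC)c1OC`. It differs from compound 2 by 4-fluorophenyl in place of 3-fluoro-4-methoxyphenyl on an aromatic carbon, with the rest of the shared core unchanged.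

Going by the values given here, only one measured step bears on this change: a 1.3-fold higher number from compound 1 to compound 2 (0.12 log units; within the scatter), with fluoro in place of methoxy on an aromatic carbon. That step is small, but it is a single exchange and does not show what happens when the methoxy leaves with no replacement. The evidence therefore points to little movement in this assay, with at most a slight drift towards weaker inhibition and wide uncertainty. The expected change is a 1.2-fold higher number from compound 2 to compound 3 (0.07 log units; within the scatter), which is not clearly beyond the scatter. The estimate for compound 3 is 2000 nM, with an expected range of 700 nM to 5500 nM.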

Compound 3, half-maximal inhibitory concentration: > 25000 nM
Compound 3 was reported as a limit; the forecaster's own chance of this, stated with the estimate: 3%; at least 12-fold (1.09 log units) between middle value and limit.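

Compound 3 is reported only as a limit, not as a number, in this assay: the limit of > 25000 nM in this assay, at which 1 of the 3 values shown sits.

On the aromatic carbon next to the ring nitrogen and the ring oxygen, 4-fluorophenyl in place of 3-fluoro-4-methoxyphenyl gives an at least 14-fold higher number from compound 2 to compound 3 (1.16 log units; beyond the scatter), and 4-fluorophenyl in place of 3,4-dimethoxyphenyl gives an at least 19-fold higher number from compound 1 to compound 3 (1.28 log units; beyond the scatter). Going by these compounds alone, the earlier exchange of fluoro for methoxy, a 1.3-fold higher number from compound 1 to compound 2 (0.12 log units; within the scatter), showed that this place tolerates one such swap, whereas these large steps show that the substitution of the phenyl ring here is not indifferent, and that among the three compounds only the one with no methoxy on this ring loses activity to this extent.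

The compounds shown do not separate the absence of the methoxy from the changed location of the fluoro, so 4-methoxyphenyl and 3-fluorophenyl at this place would each be informative. Nor do they show whether another group on this ring, such as an amine or a carboxylic acid, can stand in for the methoxy.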